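Ring in place of methyl on the aromatic carbon

The source may hold more compounds than are shown below. What is called first, only, known or untested is meant among the compounds shown, and "the series" means these compounds.

Measured so far:
compound 1 `Cc1nc(C(F)(F)F)ccc1CNC(=O)C(C)c1ccc(NS(C)(=O)=O)c(F)c1` — 387 nM
compound 2 `CC(C(=O)NCc1ccc(C(F)(F)F)nc1C1CCC(C)(C)CC1)c1ccc(NS(C)(=O)=O)c(F)c1` — 0.4 nM
compound 3 `CC(C(=O)NCc1ccc(C(F)(F)F)nc1C1CCC(F)(F)CC1)c1ccc(NS(C)(=O)=O)c(F)c1` — 1.5 nM

In an assay on CHO cells for antagonist activity at transient receptor potential cation channel subfamily V member 1 (Homo sapiens), read by FLIPR and calcium flux (on this read-out lower numbers stand for stronger inhibition and higher numbers for weaker inhibition), compound 1 gives 387 nM, the highest number of the three. Its nearest neighbour is compound 3 with 1.5 nM, its furthest compound 2 with 0.4 nM; both carry a six-membered carbon ring where compound 1 carries methyl.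

Compound 4 `CC(C(=O)NCc1ccc(C(F)(F)F)nc1C1=CCC(C(C)(C)C)CC1)c1ccc(NS(C)(=O)=O)c(F)c1` is not yet measured. It differs from compound 1 in one place: 4-(tert-butyl)cyclohex-1-en-1-yl in place of methyl on an aromatic carbon.

Going by the values given here, two measured steps bear on this change, both starting from compound 1 and both large: a 970-fold lower number from compound 1 to compound 2 (2.99 log units; beyond the scatter) and a 260-fold lower number from compound 1 to compound 3 (2.41 log units; beyond the scatter). Between the two ring-bearing compounds the difference is modest, a 3.8-fold higher number from compound 2 to compound 3 (0.57 log units; beyond the scatter), so the size of the drop has so far depended little on what sits on the ring. Compound 4 again puts a six-membered carbon ring on the same aromatic carbon, here with a double bond and a tert-butyl group. A large drop in this assay is therefore expected, of the order of the two measured steps; the estimated step is a 390-fold lower number from compound 1 to compound 4 (2.59 log units; beyond the scatter). For compound 4 the number expected in this assay is 1 nM, with a range from 0.2 nM to 6 nM.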

Compound 4, inhibition constant: 0.2 nM
Beside the measured number, compound 4's estimate is 5.0-fold (0.70 log units) above it; low and high end bracket the measured number.
By their numbers in this assay, from the lowest: compounds 4 and 2 (each within the scatter of the next); then compound 3; then compound 1.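

In this assay, a double bond in the ring and a tert-butyl group on it are both compatible with a large step at this position, next to the ring nitrogen: a 1900-fold lower number from compound 1 to compound 4 (3.29 log units; beyond the scatter). Ring substitution now separates the compounds to a limited degree, with a 7.5-fold lower number from compound 3 to compound 4 (0.88 log units; beyond the scatter) beyond the scatter and a 2.0-fold lower number from compound 2 to compound 4 (0.30 log units; within the scatter) within it, so the two rings bearing only carbon substituents, in compound 2 and compound 4, stand together and apart from the 4,4-difluorocyclohexyl ring of compound 3. No measurement on hand accounts for either the large step or the separation among the rings.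

Compound 4 differs from compound 2 and compound 3 in both ring saturation and ring substituent, so the contribution of the double bond cannot be separated from that of the tert-butyl group. Also open, as far as these compounds go, is how far the result at this aromatic carbon depends on a six-membered carbon ring at all, as opposed to an open chain such as n-butyl, a phenyl ring or a ring carrying an amine or a carboxylic acid.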